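Trimming the silicon-bearing group on compound 1

The source may report more compounds than this note shows. Statements on the series, on what has been measured and on what is new or still open speak of the compounds shown alone.

Compound 1 `C=C1CC[C@@H]2[C@](C)(CO[Si](C(C)C)(C(C)C)C(C)C)[C@H](O)CC[C@@]2(C)[C@@H]1C/C=C1/C(=O)OC[C@H]1O`: 2.85 uM
Compound 2 `C=C1CC[C@@H]2[C@](C)(CO[Si](c3ccccc3)(c3ccccc3)C(C)(C)C)[C@H](OC(C)=O)CC[C@@]2(C)[C@@H]1C/C=C1/C(=O)OC[C@H]1O`: 10.5 uM
Compound 3 `C=C1CC[C@@H]2[C@](C)(COC(C)=O)[C@H](OC(C)=O)CC[C@@]2(C)[C@@H]1C/C=C1/C(=O)OC[C@H]1OC(C)=O`: 11.4 uM

In a functional assay on ASK cells (Rattus norvegicus) for cytotoxicity, read by sulforhodamine B assay (a lower number here means that less compound is needed, a higher number that more compound is needed for the effect), compound 1 gives the lowest of the three numbers; compound 2 and compound 3 both sit well beyond the scatter above it. Compound 4 `C=C1CC[C@@H]2[C@](C)(CO[Si](C)(C)C(C)(C)C)[C@H](O)CC[C@@]2(C)[C@@H]1C/C=C1/C(=O)OC[C@H]1O` keeps the core of compound 1 and changes only one place: a group of 7 heavy atoms (6 carbon, 1 silicon; no ring) in place of a group of 10 heavy atoms (9 carbon, 1 silicon; no ring), on an oxygen on a saturated carbon. Both silicon-bearing groups lack donors and acceptors, and the two free hydroxyl groups of compound 1 are retained, so nothing in the measured set points to a large shift. A step from compound 1 to compound 4 of a 1.2-fold higher number from compound 1 to compound 4 (0.09 log units; within the scatter) is expected, which stays within the usual scatter. Compound 4 is therefore estimated at 3.5 uM in this assay, with a likely range from 1.5 uM to 9 uM.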

Compound 4, concentration for half-maximal effect: 15.5 uM
Compound 4: middle estimate off by 4.4-fold (0.65 log units), on the low side; the measured number lies above the stated range.
By their numbers in this assay, from the lowest: compound 1; then compounds 2, 3 and 4 (each within the scatter of the next).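

With the rest of compound 1 unchanged, exchanging the group of 10 heavy atoms (9 carbon, 1 silicon; no ring) for the group of 7 heavy atoms (6 carbon, 1 silicon; no ring) gives a 5.4-fold higher number from compound 1 to compound 4 (0.74 log units; beyond the scatter) in this assay. Going by these compounds alone, this is the first single-place change in the set, and it shows that the number responds to the silicon-bearing group on this oxygen. Nothing measured here explains the shift.

Within the data shown here, with only two groups compared at this oxygen, no trend with group size can be drawn. As far as these compounds go, how a benzyl ether or a triethylsilyl group on the same oxygen would read remains open.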